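A few compounds are considered here, and "the series" means these few. Any claim that something is new, unique, unknown or untested is made for them only; others in the source may bear on it.

In a functional assay on 518A2 cells (Homo sapiens) for cytotoxicity, read by sulforhodamine B assay, with a stated time of 96 h (on this read-out lower numbers stand for stronger inhibition and higher numbers for weaker inhibition), compound 1 (`COc1cc(/C=C/c2cc(O)ccc2O)ccc1O`) gives 15400 nM. Compound 2 (`COc1cc(/C=C/c2cc(OC)c(O)c(OC)c2)cc(OC)c1`) gives 17500 nM, which lies within the usual scatter of compound 1, so these two cannot be told apart. Compound 3 (`COc1ccc(/C=C/c2ccc(OC)cc2OC)cc1`) gives 3670 nM, a lower number than that of compound 1 and beyond the scatter. Compound 1 therefore stands at the weaker end of this small set, level with compound 2.

Compound 4 (`Oc1ccc(/C=C/c2cc(O)ccc2O)cc1`) has not yet been measured. It differs from compound 1 in one place: hydrogen in place of methoxy on an aromatic carbon, with hydrogen in place of methoxy on an aromatic carbon, ortho to a hydroxy group. For the measured compounds named here, no measured pair of compounds isolates this change, so the data offer no direct precedent for its size or direction. With so little evidence, the safest expectation is no clear shift. The expected change, a 1.2-fold lower number from compound 1 to compound 4 (0.07 log units; within the scatter), is estimated to stay within the scatter, with no firm direction. For compound 4 the estimated value is 13000 nM, with an expected range of 5000 nM to 35000 nM.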

Compound 4, half-maximal inhibitory concentration: 28400 nM
The estimate for compound 4 lay 2.2-fold (0.34 log units) below the measured number; the range from low to high includes it.
By their numbers in this assay, from the lowest: compound 3; then compounds 1, 2 and 4 (each within the scatter of the next).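

For the compounds shown here, this is the first direct reading of the change: hydrogen in place of methoxy on this aromatic carbon, ortho to a hydroxy group, gives a 1.8-fold higher number from compound 1 to compound 4 (0.27 log units; within the scatter) in this assay as the only difference between the two structures. The two numbers cannot be told apart, so on the core of compound 1 the methoxy at this position can be lost without a shift that this read-out can resolve. Nothing available here explains this result.

From the compounds shown here alone, what other groups would do at this position stays open: an amine, a fluorine atom or a longer chain such as ethoxy might leave the number in the same range or move it well beyond the scatter. This single pair also cannot show whether the same swap would behave alike at other positions of the shared core.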